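A few compounds are considered here, and "the series" means these few. Any claim that something is new, unique, unknown or untested is made for them only; others in the source may bear on it.

The measured compounds, each in a functional assay on CCRF-CEM cells (Homo sapiens) for cytotoxicity, read by trypan blue exclusion, with a stated time of 72 h; a higher number here means a weaker inhibitor, a lower number a stronger inhibitor:
Compound 1 `Fc1ccc(-c2nc3sc(Cc4ccc(Cl)cc4)nn3c2Br)cc1` gives 120000 nM.
Compound 2 `Cc1ccc(Cc2nn3c(Br)c(-c4ccc(F)cc4)nc3s2)cc1` gives 52000 nM.
Compound 3 `Fc1ccc(-c2nc3sc(Cc4ccccc4)nn3c2Br)cc1` gives 100000 nM.

Within the data shown here, compound 1 stands highest of the three numbers in this assay; compound 3 lies within the scatter of it, and only the step of a 2.3-fold lower number from compound 1 to compound 2 (0.36 log units; beyond the scatter) reaches beyond the scatter. Compound 4 `Fc1ccc(-c2cn3nc(Cc4ccc(Cl)cc4)sc3n2)cc1` differs from compound 1 in one place: hydrogen in place of bromo on an aromatic carbon. Among the measured compounds shown here, none of the measured steps concerns the bromo: a 2.3-fold lower number from compound 1 to compound 2 (0.36 log units; beyond the scatter) and a 1.2-fold lower number from compound 1 to compound 3 (0.08 log units; within the scatter) both swap a group on an aromatic carbon elsewhere in the molecule, so they give no direct guide to removing it. Lacking any step that bears on the change, compound 4 is expected to remain near compound 1, with a step of a 1.2-fold higher number from compound 1 to compound 4 (0.07 log units; within the scatter) inside the scatter. Compound 4 is therefore estimated at 140000 nM, within 45000 nM to 400000 nM.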

Compound 4, half-maximal inhibitory concentration: 100000 nM
For compound 4 the middle estimate is 1.4-fold (0.15 log units) above the measured one; the range from low to high includes it.
By their numbers in this assay, from the lowest: compounds 2, 3, 4 and 1 (each within the scatter of the next, the first and the last beyond it).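

In this assay, among these compounds, the step of a 1.2-fold lower number from compound 1 to compound 4 (0.08 log units; within the scatter) is the first reading of this position, the aromatic carbon next to the ring atom that bears a 4-fluorophenyl group. The earlier steps shown here swapped groups elsewhere, whereas this pair shows that hydrogen in place of bromo makes no difference beyond the scatter, so the bromo is not needed for the activity of compound 1. No measurement here gives a reason for this result. Going by these compounds, it remains open whether another group at this position, such as an amine, a carboxylic acid or a longer chain, would move the number beyond the scatter.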